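The source may report more compounds than this note shows. Statements on the series, on what has been measured and on what is new or still open speak of the compounds shown alone.

In a toxicity assay on L02 cells (Homo sapiens) for cytotoxicity, read by MTT assay, with a stated time of 72 h (a higher number here means a weaker inhibitor, a lower number a stronger inhibitor), compound 2 (`CC1(C)OCC(Cn2cc(Cn3c4c(c5ccccc53)C(=O)c3c[n+]([O-])c5ccccc5c3C4=O)nn2)O1`) gives 120 nM and stands within the scatter of compound 1 (`O=C1c2c[n+]([O-])c3ccccc3c2C(=O)c2c1c1ccccc1n2CCCCn1ccnc1`), which gives 150 nM in the same test, while compound 3 (`O=C1c2c[n+]([O-])c3ccccc3c2C(=O)c2c1c1ccccc1n2CCCCN1CCCCC1`) gives 610 nM as the highest number of the three. Compound 4 (`O=C1c2c[n+]([O-])c3ccccc3c2C(=O)c2c1c1ccccc1n2Cc1cn([C@H]2C[C@H](O)[C@@H](CO)O2)nn1`) follows from compound 2 through 4-hydroxy-5-(hydroxymethyl)oxolan-2-yl in place of (2,2-dimethyl-1,3-dioxolan-4-yl)methyl on an aromatic nitrogen on an aromatic nitrogen. For the measured compounds named here, no measured step covers this exchange. The only one available, a 4.1-fold higher number from compound 1 to compound 3 (0.61 log units; beyond the scatter) with piperidin-1-yl in place of 1H-imidazol-1-yl on a saturated chain carbon, offers only a rough scale. A small upward step in this assay that is not clearly beyond the scatter is therefore expected, with a 1.7-fold higher number from compound 2 to compound 4 (0.22 log units; within the scatter) as the estimated size. Compound 4 is estimated at 200 nM with an expected range from 60 nM to 650 nM in this test.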

Compound 4, half-maximal inhibitory concentration: 280 nM
Compound 4: the middle estimate sits 1.4-fold (0.15 log units) below what was measured; measured number inside the range.
By their numbers in this assay, from the lowest: compounds 2, 1 and 4 (each within the scatter of the next, the first and the last beyond it); then compound 3.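

At the aromatic nitrogen of the five-membered aromatic ring with 3 nitrogen, this assay proves sensitive to the substituent: 4-hydroxy-5-(hydroxymethyl)oxolan-2-yl in place of (2,2-dimethyl-1,3-dioxolan-4-yl)methyl gives a 2.3-fold higher number from compound 2 to compound 4 (0.37 log units; beyond the scatter). The two groups match in heavy atoms, yet only the entering group carries hydrogen-bond donors. No measurement available here bears on why the number rises. The compounds shown do not separate the hydroxyl groups from the change of ring, which arrive together. On these data alone, how a carboxylic acid or a simple amine at this nitrogen would read also remains open.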